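The source may report more compounds than this note shows. Statements on the series, on what has been measured and on what is new or still open speak of the compounds shown alone.

Three compounds share one core, shown by compound 1 `Oc1ccc(-c2cc(-c3ccncc3)nc(-c3cccc(Cl)c3)c2)cc1`, compound 2 `Oc1ccc(-c2cc(-c3ccsc3)nc(-c3cccc(Cl)c3)c2)cc1` and compound 3 `Oc1ccc(-c2cc(-c3ccccc3)nc(-c3cccc(Cl)c3)c2)cc1`. In a functional assay on DU-145 cells (Homo sapiens) for cytotoxicity, read by CCK-8 assay and cell counting, with a stated time of 2 days (a higher number here means a weaker inhibitor, a lower number a stronger inhibitor), compound 1 has "not determined" (no result reported), so no number is reported for it. In this assay compound 2 gives 6220 nM, the only number shown here, so it stands alone without a comparison. Compound 3 differs from compound 2 in one place: phenyl in place of thiophen-3-yl on an aromatic carbon. For the measured compounds named here, no measured pair shows what this exchange does in this assay, so compound 3 is expected to stay within the usual scatter of compound 2, with a step of a 1.0-fold lower number from compound 2 to compound 3 (0.02 log units; within the scatter). Compound 3 is therefore estimated at 6000 nM, between 2500 nM and 15000 nM.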

Compound 3, half-maximal inhibitory concentration: 5360 nM
Estimate against measurement, compound 3: 1.1-fold (0.05 log units) above; the measured number falls inside the stated range.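

Replacing thiophen-3-yl with phenyl on the aromatic carbon next to the ring nitrogen gives a 1.2-fold lower number from compound 2 to compound 3 (0.06 log units; within the scatter) in this assay. At this position, then, the sulfur-containing five-membered ring and the six-membered carbon ring cannot be told apart in this read-out. Nothing available here offers an explanation for this result.

The steps to compound 1 cannot be read, as it has no number. As far as these compounds go, what an amine, a carboxylic acid or a longer alkyl chain would do at this position remains open.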